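Terminal group changes on the alkoxy chain of the shared core

The source may hold more compounds than are shown below. What is called first, only, known or untested is meant among the compounds shown, and "the series" means these compounds.

Measured so far:
compound 1 `CCOC(=O)CCCCCOc1ccc2c(=O)c(-c3ccc(O)cc3)coc2c1`: 280 nM
compound 2 `O=c1c(-c2ccc(O)cc2)coc2cc(OCCCCCCCCCO)ccc12`: 700 nM

In an assay (Cricetulus griseus) for inhibition of aldehyde dehydrogenase, mitochondrial (Homo sapiens) (on this read-out higher numbers stand for weaker inhibition and lower numbers for stronger inhibition), compound 2 holds the highest number of the two measured; compound 1 sits lower, the step being a 2.5-fold higher number from compound 1 to compound 2 (0.40 log units; beyond the scatter). Compound 3 `O=C(O)CCCCCCCOc1ccc2c(=O)c(-c3ccc(O)cc3)coc2c1` carries carboxy in place of 2-hydroxyethyl on a saturated chain carbon, seven bonds along the chain from an oxygen on an aromatic ring. Within the data shown here, only one measured step bears on this, a 2.5-fold higher number from compound 1 to compound 2 (0.40 log units; beyond the scatter), and it changed a different terminus at a different chain position, so it guides only loosely. Among the measured compounds shown here, a carboxy terminus has no direct precedent here. The expectation is a small move toward a lower number, a 1.6-fold lower number from compound 2 to compound 3 (0.19 log units; within the scatter), not clearly beyond the scatter. Compound 3 is estimated at 450 nM, within 200 nM to 1000 nM.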

Compound 3, half-maximal inhibitory concentration: 40 nM
Compound 3: middle estimate off by 11-fold (1.05 log units), on the high side; measured number below the stated range.
By their numbers in this assay, from the lowest: compound 3; then compound 1; then compound 2.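

Carboxy in place of 2-hydroxyethyl at this chain position gives an 18-fold lower number from compound 2 to compound 3 (1.24 log units; beyond the scatter) and shows that the terminus can move this read-out far more than the earlier step suggested. 2-Carboxyethyl in place of ethoxycarbonyl points the same way with a 7.0-fold lower number from compound 1 to compound 3 (0.85 log units; beyond the scatter) and leaves compound 3 lowest of the three, though this step also changes the chain length. No measurement shown here explains the drop.

The compounds shown leave open how much of the drop belongs to the carboxy group and how much to chain length. A carboxylic acid on a shorter chain and an amide on the same chain would help separate the two.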